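The compounds below may be only part of what the source reports. "The series", "measured", "known", "first", "only" and "open" are said of these compounds alone.

Three compounds carrying the shared core of compound 1 `Cc1nc(COc2ccc(/C=C3\SC(=O)NC3=O)cc2)cs1` have been run in a functional assay on the whole organism (strain Wistar) with Rattus norvegicus as the target, with a stated time of 15 days, at a dose of 3 mg/kg by the oral route; a lower number here means a weaker effect, a higher number a stronger effect of the compound at the dose given. Compound 1 gives 18.6%. Among the measured compounds shown here, compound 2 `O=C1NC(=O)/C(=C/c2ccc(OCc3csc(-c4ccccc4)n3)cc2)S1` gives 25.2%, and the single one-place step measured, a number 6.6 percentage points higher from compound 1 to compound 2 (within the scatter), lies within the scatter. Compound 3 `O=C1NC(=O)/C(=C/c2ccc(OCCSc3nnc(-c4ccc([N+](=O)[O-])cc4)[nH]3)cc2)S1` gives 14.1%, the lowest of the three numbers shown; the gap to compound 1, the nearest, is within the scatter, while the gap to compound 2, the furthest, is beyond it.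

Compound 4 `COc1ccc(-c2nnc(SCCOc3ccc(/C=C4\SC(=O)NC4=O)cc3)[nH]2)cc1` is not yet measured. From compound 3 to compound 4 the change is methoxy in place of nitro on an aromatic carbon. For the measured compounds named here, no measured step touches this position or this pair of groups; the only step measured, a number 6.6 percentage points higher from compound 1 to compound 2 (within the scatter), sits on another part of the molecule and stays within the scatter, so it offers no direction for the present change. With nothing bearing on it, the expected step in this assay is a number 2.9 percentage points higher from compound 3 to compound 4 (within the scatter), which means none beyond the scatter. Compound 4 is therefore estimated at 17%, with a range from 8% to 28%.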

Compound 4, a percentage reported as activity, at one dose (the size of the read-out at that dose, not a potency): 43.1%
Compound 4: middle estimate off by 26.1 percentage points, on the low side; the whole stated range lies below it.
By their numbers in this assay, from the lowest: compounds 3, 1 and 2 (each within the scatter of the next, the first and the last beyond it); then compound 4.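

The position para to a large group on the six-membered aromatic ring of carbon only responds in this assay: methoxy in place of nitro gives a number 29 percentage points higher from compound 3 to compound 4 (beyond the scatter). Among the compounds shown here, this is the first one-place step beyond the scatter, whereas phenyl in place of methyl, at a different place, gave only a number 6.6 percentage points higher from compound 1 to compound 2 (within the scatter). Nothing measured on these compounds accounts for the size or direction of the 4-nitrophenyl to 4-methoxyphenyl step.

With a single pair at this position, the compounds shown do not separate the departure of nitro from the arrival of methoxy. An unsubstituted phenyl, an amine or a longer alkoxy chain such as ethoxy at the same place would show which of the two carries the step, and whether the position tolerates larger groups.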